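This account rests on a few compounds, and the source may have more. Where it says the series, first, only, none or still open, it means among the compounds named here.

In a functional assay on the whole organism (blood) with Rattus norvegicus as the target, with stated times of 24 h and 1 h, at a dose of 5 mg/kg by the intraperitoneal route (a higher number here means a stronger effect of the compound at the dose given, a lower number a weaker effect), two compounds of this series have been measured. Compound 1 `COc1ccc(Cl)cc1C(=O)NCCC1CCN(S(=O)(=O)NC(=O)NC[C@@H]2C[C@@H]3CC[C@@H]2O3)CC1` gives 30% in this assay. Compound 2 `Cc1cccc(C(=O)NCCC2CCN(S(=O)(=O)NC(=O)NC[C@@H]3C[C@@H]4C=C[C@@H]3C4)CC2)n1` gives 20% in this assay. Compound 2 thus has the smaller of the two numbers, but its distance to compound 1 lies within the scatter of repeated measurements, so the two cannot be told apart on the numbers alone. Within the data shown here, no pair of measured compounds differs in only one place, so no isolated structural effect can be read from the data.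

Compound 3 `O=C(NC[C@@H]1C[C@@H]2C=C[C@@H]1C2)NS(=O)(=O)N1CCC(CCNC(=O)c2cc(Cl)cc3cccnc23)CC1` has not yet been measured in this assay. It differs from compound 2 in one place: 6-chloroquinolin-8-yl in place of 6-methylpyridin-2-yl on a carbonyl carbon. Since compound 1 and compound 2 give numbers within the scatter of each other, and no comparable change has been measured, the step from compound 2 to compound 3 is expected to be small, a number 8 percentage points higher from compound 2 to compound 3 (within the scatter), and not clearly beyond the scatter in either direction. Compound 3 is therefore estimated to give about 28% in this assay, with a range from 8% to 52%.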

Compound 3, a percentage reported as activity, at one dose (the size of the read-out at that dose, not a potency): 35%
Compound 3: the middle estimate sits 7 percentage points below what was measured, and the stated range covers the measured number.
By their numbers in this assay, from the lowest: compounds 2, 1 and 3 (each within the scatter of the next, the first and the last beyond it).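

In this assay, among these compounds, the aromatic group on the carbonyl carbon is the first place where a single change can be read: 6-chloroquinolin-8-yl in place of 6-methylpyridin-2-yl gives a number 15 percentage points higher from compound 2 to compound 3 (beyond the scatter), a modest step, but one that clears the scatter. With the rest of compound 2 unchanged, the result shows that the effect at the given dose responds to the group at this place, and that the larger group, with 11 heavy atoms instead of 7 and a carbon-only aromatic ring added to the ring with the hetero atom, is accepted with no loss of effect. No measurement at hand gives a reason for this step.

This one step changes the ring count and brings in chlorine together, so it leaves open how much belongs to each, which quinolin-8-yl without the chlorine, or 6-chloropyridin-2-yl, could separate. It also leaves open whether the place tolerates a group of another kind, such as a carboxylic acid or an amine on the aromatic ring, and compound 1 differs from compound 3 in more than one place, so it adds nothing to this reading.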